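Fluorophenyl carbamate variation on the shared core

The source may report more compounds than this note shows. Statements on the series, on what has been measured and on what is new or still open speak of the compounds shown alone.

Measured so far:
compound 1 `COc1cccc(NC(=O)Oc2cc(=O)n(CCCO)c3c2CC(C/C=C(\C)CCC=C(C)C)C(C)(C)C3)c1`, 11.3%
compound 2 `CC(C)=CCC/C(C)=C/CC1Cc2c(OC(=O)Nc3cccc(F)c3)cc(=O)n(CCCO)c2CC1(C)C`, 0%

In a functional assay on PANC-1 cells (Homo sapiens) for inhibition, read by MTT assay, with a stated time of 24 h, tested at 10 uM (on this read-out lower numbers stand for less inhibition and higher numbers for more inhibition at the one concentration tested (going by the name of the read-out)), compound 1 gives 11.3% while compound 2 gives 0%. For the measured compounds named here, the one measured step, a number 11.3 percentage points lower from compound 1 to compound 2 (beyond the scatter), is the only comparison available. Going by the values given here, compound 2 therefore stands lowest of the two numbers, with compound 1 its only neighbour, higher beyond the scatter.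

Compound 3 `CC(C)=CCC/C(C)=C/CC1Cc2c(OC(=O)Nc3ccccc3F)cc(=O)n(CCCO)c2CC1(C)C` is not yet measured in this assay. Relative to compound 2 the change is 2-fluorophenyl in place of 3-fluorophenyl on an amide-type nitrogen. Among the compounds with values here, no measured step bears directly on this rearrangement: the one known step exchanges the group itself rather than its position on the ring, and it was modest. With compound 2 already at the bottom of the read-out, a step of more than a few points in either direction is not expected. Compound 3 is expected to give about 5%, within 0% to 18%. This corresponds to an expected step of a number 5 percentage points higher from compound 2 to compound 3 (within the scatter), within the scatter.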

Compound 3, a percentage reported as inhibition, at one concentration (the size of the read-out at that concentration, not a potency): 0%
The estimate for compound 3 lay 5 percentage points above the measured number; measured number inside the range.
By their numbers in this assay, from the lowest: compounds 2 and 3 (each within the scatter of the next); then compound 1.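

In this assay, moving the fluoro group from 3-fluorophenyl to 2-fluorophenyl on the amide-type nitrogen gives no change at the digits printed from compound 2 to compound 3 (within the scatter), so the two fluorophenyl compounds cannot be told apart, although a number at the bottom of the read-out could hide any further loss. The replacement of 3-methoxyphenyl by 2-fluorophenyl gives a number 11.3 percentage points lower from compound 1 to compound 3 (beyond the scatter), so both fluorophenyl compounds, not only compound 2, now lie beyond the scatter below compound 1. No measurement here explains these results.

The compounds shown leave open whether any group on this ring can raise the number well above that of compound 1, which is itself modest at 11.3%. A phenyl group carrying an amine or a carboxylic acid on the amide-type nitrogen would test this.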